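Adding one more methyl to the nitrogen chain

The source may report more compounds than this note shows. Statements on the series, on what has been measured and on what is new or still open speak of the compounds shown alone.

Measured so far in a functional assay (Homo sapiens) for inhibition, with a stated time of 72 h; on this read-out higher numbers stand for weaker inhibition and lower numbers for stronger inhibition:
compound 1 (`COc1cc(C(=O)c2ccc3c(ccn3C)c2)cc(OC)c1OC`): 12.5 nM
compound 2 (`CCn1ccc2cc(C(=O)c3cc(OC)c(OC)c(OC)c3)ccc21`): 40 nM

Of these two compounds, compound 2 has the higher number, 40 nM, and therefore the weaker inhibition. Compound 3 (`COc1cc(C(=O)c2ccc3c(ccn3C(C)C)c2)cc(OC)c1OC`) keeps the shared core, but its ethyl becomes isopropyl: methyl in place of hydrogen on a saturated chain carbon bound to an aromatic nitrogen and a saturated chain carbon. In words, this is methyl in place of hydrogen on a saturated chain carbon bound to an aromatic nitrogen and a saturated chain carbon.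

Among the measured compounds shown here, only one measured step bears on this change. It also places a methyl on a saturated chain carbon bound to an aromatic nitrogen, and it is modest but beyond the scatter: a 3.2-fold higher number from compound 1 to compound 2 (0.51 log units; beyond the scatter). A single step is thin evidence, so a step of similar size toward a higher number is expected in this assay, with wide uncertainty. The expected step is a 2.5-fold higher number from compound 2 to compound 3 (0.40 log units; beyond the scatter). For compound 3 the estimate is 100 nM, with an expected range of 35 nM to 280 nM.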

Compound 3, half-maximal inhibitory concentration: 1600 nM
For compound 3 the middle estimate is 16-fold (1.20 log units) below the measured one; the whole stated range lies below it.
By their numbers in this assay, from the lowest: compound 1; then compound 2; then compound 3.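

The second added methyl does not repeat the first: in this assay, ethyl to isopropyl gives a 40-fold higher number from compound 2 to compound 3 (1.60 log units; beyond the scatter), a large step, whereas methyl to ethyl on the aromatic nitrogen gave only the modest 3.2-fold higher number from compound 1 to compound 2 (0.51 log units; beyond the scatter). Taken whole, isopropyl in place of methyl on that nitrogen gives a 130-fold higher number from compound 1 to compound 3 (2.11 log units; beyond the scatter), so across these three compounds the number rises with each added methyl, but the rise is far from even. Nothing available here explains why this one methyl matters so much.

The compounds shown leave open whether an unbranched propyl chain would behave more like ethyl or like isopropyl, so chain length and branching cannot yet be told apart. Also open, as far as these compounds go, is what a plain hydrogen or a cyclopropyl group on that nitrogen would give.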